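Dropping the triazole side chain from a pentacyclic quinone core

The source may report more compounds than this note shows. Statements on the series, on what has been measured and on what is new or still open speak of the compounds shown alone.

Measured compounds in a functional assay on A-375 cells (Homo sapiens) for cytotoxicity, read by MTT assay, with a stated time of 72 h; a lower number here means a stronger inhibitor, a higher number a weaker inhibitor:
compound 1 `O=C1c2c[n+]([O-])c3ccccc3c2C(=O)c2c1c1ccccc1n2Cc1cn(C[C@H](O)CO)nn1` gives 350 nM;
compound 2 `CC1(C)OC[C@@H](Cn2cc(Cn3c4c(c5ccccc53)C(=O)c3c[n+]([O-])c5ccccc5c3C4=O)nn2)O1` gives 450 nM;
compound 3 `O=C1c2c[n+]([O-])c3ccccc3c2C(=O)c2c1c1ccccc1n2Cc1cn([C@@H]2O[C@H](CO)[C@@H](O)[C@H](O)[C@H]2O)nn1` gives 230 nM.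

Compound 1 differs from compound 2 by a 1.3-fold higher number from compound 1 to compound 2 (0.11 log units; within the scatter) and from compound 3 by a 1.5-fold lower number from compound 1 to compound 3 (0.18 log units; within the scatter), so all three numbers sit within the scatter of one another. Compound 4 `O=C1c2c[n+]([O-])c3ccccc3c2C(=O)c2[nH]c3ccccc3c21` carries hydrogen in place of (1-(2,3-dihydroxypropyl)-1H-1,2,3-triazol-4-yl)methyl on an aromatic nitrogen. Among the compounds with values here, no measured step removes this group: the steps of a 1.3-fold higher number from compound 1 to compound 2 (0.11 log units; within the scatter), a 1.5-fold lower number from compound 1 to compound 3 (0.18 log units; within the scatter) and a 2.0-fold lower number from compound 2 to compound 3 (0.29 log units; within the scatter) only reshape its outer part, each within the scatter. As far as these compounds go, those three steps suggest the substituent matters little, but its complete removal is untested, so the expectation is broad. For compound 4 the expected step is a 1.1-fold higher number from compound 1 to compound 4 (0.06 log units; within the scatter). Compound 4 is estimated at 400 nM, with a range of 120 nM to 1500 nM.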

Compound 4, half-maximal inhibitory concentration: 660 nM
Beside the measured number, compound 4's estimate is 1.7-fold (0.22 log units) below it; measured number inside the range.
By their numbers in this assay, from the lowest: compounds 3, 1, 2 and 4 (each within the scatter of the next, the first and the last beyond it).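

In this assay, hydrogen in place of the whole (1-(2,3-dihydroxypropyl)-1H-1,2,3-triazol-4-yl)methyl group on the aromatic nitrogen gives a 1.9-fold higher number from compound 1 to compound 4 (0.28 log units; within the scatter) and so stays within the scatter. Removing the side chain entirely, and not only reshaping its outer part, therefore leaves the cytotoxicity of compound 4 comparable to that of compound 1. Nothing available explains this result.
As far as these compounds go, whether an amine or a carboxylic acid on the triazole, or a longer chain on this nitrogen, would move the number beyond the scatter stays open.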